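A Nitrogen-Bearing Chain in a Series Stuck at Its Limit

The compounds below may be only part of what the source reports. "The series", "measured", "known", "first", "only" and "open" are said of these compounds alone.

Measured in a functional assay on DU-145 cells (Homo sapiens) for antiproliferative activity, read by WST assay, with a stated time of 3 days; on this read-out lower numbers stand for stronger inhibition and higher numbers for weaker inhibition:
Compound 1 `CCCCOc1c(-c2cc(OC)c(OC)c(OC)c2)oc2ccccc2c1=O` gives > 50000 nM as a limit
Compound 2 `CCCCCOc1c(-c2cc(OC)c(OC)c(OC)c2)oc2ccccc2c1=O` gives > 50000 nM as a limit
Compound 3 `CCCC(C)Oc1c(-c2cc(OC)c(OC)c(OC)c2)oc2ccccc2c1=O` gives > 50000 nM as a limit

Compound 3 has only a limit to show, and the same limit is shared across the series the limit of > 50000 nM in this assay, at which 3 of the 3 values shown sit, so these compounds cannot be ranked. For the measured compounds named here, compound 4 `CCN(CC)CCCCCOc1c(-c2cc(OC)c(OC)c(OC)c2)oc2ccccc2c1=O` keeps the shared core but carries 5-(diethylamino)pentyl in place of 1-methylbutyl on an oxygen on an aromatic ring and it is the only compound here whose chain holds nitrogen. Going by the values given here, three measured steps bear on this change, and each swaps one plain carbon chain for another: a step that the two limits leave unreadable from compound 1 to compound 2 and a step that the two limits leave unreadable from compound 1 to compound 3 and a step that the two limits leave unreadable from compound 2 to compound 3 offer no size to carry over. A move toward stronger inhibition is still expected, resting on the new chain alone, though another limit remains possible. In this assay the expected change is an at least 5.0-fold lower number from compound 3 to compound 4 (0.69 log units; beyond the scatter) and it is only an estimate. Compound 4 is expected at 10000 nM with an estimated range from 2500 nM to 40000 nM for this measurement.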

Compound 4, half-maximal inhibitory concentration: 33400 nM
The estimate for compound 4 lay 3.3-fold (0.52 log units) below the measured number; measured number inside the range.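

Placed on the oxygen on the aromatic ring, 5-(diethylamino)pentyl gives the only number in this assay that is not a limit, so the series can now be read for the first time, whereas the plain carbon chains stay out of reach: the limit of > 50000 nM in this assay, at which 3 of the 4 values shown sit. Measured against those chains, the change reads as an at least 1.4-fold lower number from compound 3 to compound 4 (0.17 log units; that floor lies within the scatter), as an at least 1.4-fold lower number from compound 2 to compound 4 (0.17 log units; that floor lies within the scatter) and as an at least 1.4-fold lower number from compound 1 to compound 4 (0.17 log units; that floor lies within the scatter). Each size is only a floor, so the true gain could be small or much larger.

From the compounds shown here alone, it remains open how much the length of the chain matters once the amine is in place, which a shorter chain carrying diethylamino could test. A ring amine such as piperidine or morpholine at the chain end could show whether the kind of amine changes the number.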